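The source may hold more compounds than are shown below. What is called first, only, known or untested is meant among the compounds shown, and "the series" means these compounds.

Antagonist activity here is measured in a functional assay on HEK293 cells for antagonist activity at metabotropic glutamate receptor 5 (Homo sapiens), read by FLIPR and calcium flux; on this read-out lower numbers stand for stronger inhibition and higher numbers for weaker inhibition. Compound 1 `N#Cc1cccc(C(=O)N[C@@H]2CCC[C@@H](NC(=O)c3ccccn3)C2)c1` gives 231 nM in this assay, and compound 2 `O=C(N[C@@H]1CCC[C@@H](NC(=O)c2ccccn2)C1)c1cccc(Cl)c1` gives 62 nM. The difference between them is chloro in place of cyano on an aromatic carbon, which made a 3.7-fold lower number from compound 1 to compound 2 (0.57 log units; beyond the scatter). Compound 3 `N#Cc1cccc(C(=O)N[C@@H]2CCC[C@@H](C(=O)Nc3ccccn3)C2)c1` holds the same atoms as compound 1 joined differently; the difference between the two cores is not broken down here. In this assay compound 3 gives > 10000 nM, which is a limit of the assay rather than a number. Within the data shown here, compound 4 `O=C(N[C@@H]1CCC[C@@H](C(=O)Nc2ccccn2)C1)c1cccc(Cl)c1` has no measurement yet. It differs from compound 3 by chloro in place of cyano on an aromatic carbon, the same change at the same place as between compound 1 and compound 2. Resting on a 3.7-fold lower number from compound 1 to compound 2 (0.57 log units; beyond the scatter) and on compound 3 sitting at the limit of > 10000 nM in this assay, at which 1 of the 3 values shown sits, the step from compound 3 to compound 4 is expected to be an at least 1.2-fold lower number from compound 3 to compound 4 (0.09 log units; that floor lies within the scatter). Compound 4 is therefore estimated near 8000 nM, likely between 2000 nM and 30000 nM, with a real chance that only a limit is reported again.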

Compound 4, half-maximal inhibitory concentration: 5000 nM
Beside the measured number, compound 4's estimate is 1.6-fold (0.20 log units) above it; measured number inside the range.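

In this assay, the change from nitrile to chloro on the core of compound 3 gives an at least 2.0-fold lower number from compound 3 to compound 4 (0.30 log units; that floor lies within the scatter). This fits the same direction seen on the core of compound 1, but it does not show that the two steps match or differ in size: the same change on two cores in this assay, a 3.7-fold lower number (0.57 log units; beyond the scatter) from compound 1 to compound 2 and an at least 2.0-fold lower number (0.30 log units; that floor lies within the scatter) from compound 3 to compound 4; the limit leaves it open whether they differ. Going by these compounds, compound 3 is a limit of the assay and not a number, so the true size of this step stays unknown: the limit of > 10000 nM in this assay, at which 1 of the 4 values shown sits.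

The compounds shown leave open whether other groups in this place on the aromatic ring, such as an amine or a methoxy group, would carry from one core to the other. Among these compounds, they also test this change on only two cores, so its behaviour on any other core remains unknown.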